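Acid dissociation across a three-compound series and an isobutyl analogue

The source may hold more compounds than are shown below. What is called first, only, known or untested is meant among the compounds shown, and "the series" means these compounds.

Measured so far in a physicochemical assay for acid dissociation:
compound 1, `COc1ccc(Oc2ccc3c(NCCCNCc4cccc(OC)c4O)ccnc3c2)cc1`, gives 9.28
compound 2, `COc1cccc(CNCCCNc2ccnc3cc(Cc4ccc(F)cc4)ccc23)c1O`, gives 9.47
compound 3, `COc1cccc(CNCCCNc2ccnc3cc(Oc4ccc(C(C)(C)C)cc4)ccc23)c1O`, gives 9.28

Compound 3 stands level with compound 1 at the digits printed, the two together the lowest of the three numbers; its nearest neighbour is compound 1, no change at the digits printed from compound 1 to compound 3 (within the scatter), and its furthest is compound 2, a number 0.19 log units lower from compound 2 to compound 3 (within the scatter). Every step measured so far lies within the scatter: a number 0.19 log units higher from compound 1 to compound 2 (within the scatter) as well as the two just given.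

Compound 4, `COc1cccc(CNCCCNc2ccnc3cc(CC(C)C)ccc23)c1O`, is not yet measured. It differs from compound 3 in one place: isobutyl in place of 4-(tert-butyl)phenoxy on an aromatic carbon. Within the data shown here, the steps that bear on this change are those that also alter the group on that aromatic carbon of the shared core, namely 1>2, 1>3 and 2>3. None of them moved the acid dissociation constant beyond the scatter, whether an aryl ether was exchanged for a benzyl group or one aryl substituent for another. The group being exchanged again sits on the same carbon of the core, so for compound 4 no step beyond the scatter is expected in this assay, a number 0.07 log units higher from compound 3 to compound 4 (within the scatter).

For compound 4 the estimate is therefore 9.35, expected to fall between 9 and 9.7.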

Compound 4, acid dissociation constant: 9.47
Compound 4: middle estimate off by 0.12 log units, on the low side, and the stated range covers the measured number.
By their numbers in this assay, from the lowest: compounds 1, 3, 2 and 4 (each within the scatter of the next).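

In this assay, this aromatic carbon of the shared core now carries a group with no ring: isobutyl, with 4 heavy atoms, takes the place of 4-(tert-butyl)phenoxy, with 11 heavy atoms, one six-membered aromatic ring and 1 hydrogen-bond acceptor, giving a number 0.19 log units higher from compound 3 to compound 4 (within the scatter). The exchange of 4-methoxyphenoxy for isobutyl gives a number 0.19 log units higher from compound 1 to compound 4 (within the scatter), and the exchange within the benzyl-type link, isopropyl in place of 4-fluorophenyl on the saturated chain carbon, gives no change at the digits printed from compound 2 to compound 4 (within the scatter), so removing the aromatic ring from the group at this position produces no step beyond the scatter in any of the three comparisons. Nothing in the available data accounts for this lack of response.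

Going by these compounds, whether an amine or a carboxylic acid on this aromatic carbon would give a step beyond the scatter remains open, as does the outcome for a longer chain. On these data alone, all four compounds share the rest of the structure, so the response of this number to a change elsewhere in the molecule is also open.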